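Ring size of the basic amine and Vero tolerance

The source may hold more compounds than are shown below. What is called first, only, known or untested is meant among the compounds shown, and "the series" means these compounds.

The shared core of compound 1 `CN1CCN(CC(=O)Nc2ccc(-c3nc4cc(Cl)c(Cl)cc4[nH]3)cc2)CC1` carries a 4-methylpiperazin-1-yl on a saturated chain carbon bound to a carbonyl carbon. In an ADME assay on Vero cells (Chlorocebus sabaeus) for cytotoxicity (a higher number here means that more compound is tolerated, a lower number that less compound is tolerated), compound 1 sits at a limit of the assay, > 100000 nM. Compound 2 `O=C(CN1CCCC1)Nc1ccc(-c2nc3cc(Cl)c(Cl)cc3[nH]2)cc1` likewise sits at a limit of this assay, giving > 100000 nM. The step that the two limits leave unreadable from compound 1 to compound 2 is therefore not readable in size, as both values rest on (the limit of > 100000 nM in this assay, at which 2 of the 2 values shown sit). Compound 3 `O=C(CN1CCCCC1)Nc1ccc(-c2nc3cc(Cl)c(Cl)cc3[nH]2)cc1` differs from compound 2 by piperidin-1-yl in place of pyrrolidin-1-yl on a saturated chain carbon bound to a carbonyl carbon. Within the data shown here, no measured step bears readably on this change; the only comparison, from compound 1 to compound 2, stays hidden behind the limit. The expectation is that compound 3 again reaches the limit rather than showing a step beyond the scatter, so the step of a number no higher from compound 2 to compound 3 (the limit leaves the size open) is expected to be flat. Compound 3 is estimated at 100000 nM, within 40000 nM to 300000 nM.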

Compound 3, half-maximal cytotoxic concentration: > 100000 nM
Compound 3 gave a limit, no number; the forecaster's own chance of this, stated with the estimate: 80%; the middle value sits exactly at the limit.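

In this assay, among these compounds, compound 3 gives a limit (> 100000 nM), not a number, so no step among compound 1, compound 2 and compound 3 can be read: (the limit of > 100000 nM in this assay, at which 3 of the 3 values shown sit). The compounds shown leave open whether these three differ at all in this assay, and at what concentration any of them becomes cytotoxic.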